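Swapping 2-carboxyethyl for 4-methylphenyl on a carbonyl carbon

The source may hold more compounds than are shown below. What is called first, only, known or untested is meant among the compounds shown, and "the series" means these compounds.

Measured in a functional assay on MDA-MB-231 cells (Homo sapiens) for antiproliferative activity, read by MTT assay, with a stated time of 72 h; on this read-out lower numbers stand for stronger inhibition and higher numbers for weaker inhibition:
- Compound 1 `CC1=CCC2C(CC[C@@]2(C)O)C(C)(C)C1CC[C@@H]1[C@@]2(C)CC[C@@H](O)C(C)(C)O[C@@H]2CC[C@]1(C)O`: > 50000 nM, a limit of the assay and not a number
- Compound 2 `CC1=CC[C@H]2[C@H](CC[C@]2(C)O)C(C)(C)[C@@H]1CC[C@H]1[C@]2(C)CC[C@H](OC(=O)c3ccc(Cl)cc3)C(C)(C)O[C@H]2CC[C@@]1(C)O`: 10300 nM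
- Compound 3 `CC1=CC[C@H]2[C@@H]1CC=C(C)[C@@H](CC[C@H]1[C@]3(C)CC[C@H](OC(=O)CCC(=O)O)C(C)(C)O[C@H]3CC[C@@]1(C)O)C2(C)C`: 29600 nM

Of the two true numbers, compound 3 has the higher, so it is the weaker inhibitor of the pair. Its gap to compound 2 lies beyond the usual scatter.

Compound 4 `CC1=CC[C@H]2[C@@H]1CC=C(C)[C@@H](CC[C@H]1[C@]3(C)CC[C@H](OC(=O)c4ccc(C)cc4)C(C)(C)O[C@H]3CC[C@@]1(C)O)C2(C)C` carries 4-methylphenyl in place of 2-carboxyethyl on a carbonyl carbon. Among the measured compounds shown here, no measured pair isolates this change. The nearest guide is compound 2, which also has an aromatic ring on that carbonyl, though its core differs, and gives 10300 nM. A moderate fall beyond the scatter is therefore expected in this assay, with an estimated 2.3-fold lower number from compound 3 to compound 4 (0.36 log units; beyond the scatter). The estimate for compound 4 is 13000 nM, with an expected range of 5000 nM to 32000 nM.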

Compound 4, half-maximal inhibitory concentration: 32700 nM
For compound 4 the middle estimate is 2.5-fold (0.40 log units) below the measured one, outside the stated range (above it).
By their numbers in this assay, from the lowest: compound 2; then compounds 3 and 4 (each within the scatter of the next). At a limit, above all of these: compound 1.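

On this carbonyl carbon, 4-methylphenyl in place of 2-carboxyethyl makes no readable difference in this assay, with a 1.1-fold higher number from compound 3 to compound 4 (0.04 log units; within the scatter). A ringless chain with a hydrogen-bond donor and an aromatic ring of carbon only therefore read alike here, so this change alone does not move the number. Neither compound 3 nor compound 4 sits at the limit, so the step is read between true numbers: the limit of > 50000 nM in this assay, at which 1 of the 4 values shown sits.

Still open, going by these compounds, is whether an amine or a longer chain at this position would shift the number in this assay.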